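The source may report more compounds than this note shows. Statements on the series, on what has been measured and on what is new or still open speak of the compounds shown alone.

Measured so far:
Compound 1 `Cc1cc(=O)oc2c1c(C)nn2CCO`: in a functional assay on the whole organism with Mus musculus as the target, in the writhing test (on this read-out lower numbers stand for an effect already at smaller amounts and higher numbers for an effect only at larger amounts of compound), compound 1 gives 100 mg/kg.
Compound 2 `CCCCCn1nc(C)c2c(C)cc(=O)oc21`: compound 2 reaches only a limit of the assay, > 100 mg/kg.
Compound 3 `Cc1cc(=O)oc2c1c(C)nn2C`: compound 3 gives 11.6 mg/kg.

Compound 3 thus holds the lowest of the two numbers that were read; the nearest other number belongs to compound 1, and the gap an 8.6-fold lower number from compound 1 to compound 3 (0.94 log units; beyond the scatter) lies beyond the scatter. The remaining value is a limit and leaves its own distance open.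

Compound 4, `CCCCn1nc(C)c2c(C)cc(=O)oc21`, differs from compound 3 by propyl in place of hydrogen on a saturated chain carbon bound to an aromatic nitrogen. Within the data shown here, two measured steps bear on this change. The step of an at least 8.6-fold lower number from compound 2 to compound 3 (0.93 log units; beyond the scatter) takes a chain off the same carbon and lowers the number, its size cut off only by the limit (the limit of > 100 mg/kg in this assay, at which 1 of the 3 values shown sits). The step of a number no lower from compound 1 to compound 2 (the limit leaves the size open), which lengthens the chain two bonds further out, likewise fails to lower the number. Read in reverse, the first of these steps suggests that putting chain length back onto this carbon raises the number by a modest amount at least.

Compound 4 is therefore expected to give about 90 mg/kg in this assay, with a range from 30 mg/kg to 300 mg/kg. The step this estimate implies, a 7.8-fold higher number from compound 3 to compound 4 (0.89 log units; beyond the scatter), is expected to be a rise beyond the scatter, and an outcome that ends at a limit rather than a number is thought quite possible.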

Compound 4, dose for half-maximal effect: > 100 mg/kg
Compound 4 gave a limit, no number; the forecaster's own chance of this, stated with the estimate: 50%; at least 1.1-fold (0.04 log units) between middle value and limit.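

Propyl in place of hydrogen on a saturated chain carbon bound to an aromatic nitrogen gives an at least 8.6-fold higher number from compound 3 to compound 4 (0.93 log units; beyond the scatter) in this assay, so the low number of compound 3 is already lost with a chain shorter than that of compound 2. Ethyl in place of hydroxy, two bonds along the chain from an aromatic nitrogen, gives a number no lower from compound 1 to compound 4 (the limit leaves the size open), so a plain chain of this length does not bring the number down from where the hydroxy-bearing chain leaves it, though the limit hides how far it may rise. Compound 2 and compound 4 both rest at a limit, and the step between them cannot be read: the limit of > 100 mg/kg in this assay, at which 2 of the 4 values shown sit.

Still open, on these data alone, is how the number moves with an ethyl or a propyl group in place of the methyl of compound 3, which would show how much chain this position bears before the number climbs to the limit. Also open, as far as these compounds go, is whether an amine or a carboxylic acid at the end of the chain would give a lower number than compound 1 gives, 100 mg/kg.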